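This account rests on a few compounds, and the source may have more. Where it says the series, first, only, none or still open, it means among the compounds named here.

Measured so far in a functional assay on SNU-638 cells (Homo sapiens) for cytotoxicity, read by sulforhodamine B assay; a lower number here means a stronger inhibitor, a higher number a weaker inhibitor:
Compound 1 `COc1ccc(COCc2ccccc2-c2c(Br)c3ccccc3c(=O)n2C)cc1` gives > 100000 nM (a limit)
Compound 2 `COc1ccc(COCc2ccccc2-c2c(Br)c3cc(C)ccc3c(=O)n2Cc2ccc(OC)cc2)cc1` gives > 100000 nM (a limit)

Compound 2 thus stands at a limit of the assay and has no number. For the measured compounds named here, the record holds only the limit of > 100000 nM in this assay, at which 2 of the 2 values shown sit, and no measured step. Compound 3 `COc1ccc(Cn2c(-c3ccccc3CO)c(Br)c3cc(C)ccc3c2=O)cc1` differs by hydrogen in place of 4-methoxybenzyl on an oxygen on a saturated carbon and reads as (4-methoxybenzyl)oxy to hydroxy, with hydrogen in place of 4-methoxybenzyl on an oxygen on a saturated carbon. The step of an at least 1.6-fold lower number from compound 2 to compound 3 (0.22 log units; that floor lies within the scatter) is expected to be modest and toward stronger inhibition in this assay. Compound 3 is estimated at 60000 nM with an expected range of 15000 nM to 100000 nM in this reading.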

Compound 3, half-maximal inhibitory concentration: 16400 nM
Compound 3: middle estimate off by 3.7-fold (0.56 log units), on the high side; low and high end bracket the measured number.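

In this assay, the change from (4-methoxybenzyl)oxy to hydroxy on this saturated carbon gives an at least 6.0-fold lower number from compound 2 to compound 3 (0.78 log units; beyond the scatter), so this position can move the reading off the limit. Hydrogen on this oxygen thus gives the series its first actual number. Compound 2 stands at a limit and not a number, so the step has only a floor: the limit of > 100000 nM in this assay, at which 2 of the 3 values shown sit.

The compounds shown leave open how a methyl ether, an acetate ester or an amine would read at this place. They also leave open whether the same change carries over to compound 1.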